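The source may report more compounds than this note shows. Statements on the series, on what has been measured and on what is new or still open speak of the compounds shown alone.

Of the compounds shown here, three have been measured in a functional assay on the whole organism with Rattus norvegicus as the target, at a dose of 40 mg/kg by the intraperitoneal route; a lower number here means less inhibition, a higher number more inhibition at the dose given (going by the name of the read-out). Compound 1 `CC(C)(C)c1nc2c(OCc3ccccc3)cccn2c1N` gives 0%, compound 2 `Cc1nc2c(OCc3ccccc3)nccn2c1N` gives 79%, and compound 3 `CC(=O)Nc1c(C)nc2c(OCc3ccccc3)cccn12` gives 93%. Compound 3 stands highest of the three: its nearest neighbour in the numbers is compound 2, which lies below it by more than the usual scatter, and compound 1 lies far beneath both. Compound 4 `CNC(=O)Nc1c(C)nc2c(OCc3ccccc3)cccn12` has not yet been measured in this assay. It differs from compound 3 in one place: methylamino in place of methyl on a carbonyl carbon. Put another way, acetamido becomes (methylcarbamoyl)amino. Among the compounds with values here, no step between measured compounds matches this change, so nothing measured tells its size. Compound 4 is expected to give about 82%, somewhere between 55% and 97%. The step is expected to stay within the scatter, a number 11 percentage points lower from compound 3 to compound 4 (beyond the scatter), because compound 3 already gives 93%.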

Compound 4, a percentage reported as inhibition, in the whole organism at one dose (the size of the read-out at that dose, not a potency): 22%
Compound 4: middle estimate off by 60 percentage points, on the high side, outside the stated range (below it).
By their numbers in this assay, from the lowest: compound 1; then compound 4; then compound 2; then compound 3.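

In this assay, the one-place change on the carbonyl carbon, from acetamido to (methylcarbamoyl)amino, gives a number 71 percentage points lower from compound 3 to compound 4 (beyond the scatter). Within the data shown here, this is the first comparison in the set with the rest of the structure held constant, and it shows that the effect at this dose depends strongly on the group at this position. Nothing available accounts for the drop. As far as these compounds go, it remains open whether the loss follows the nitrogen or the larger group; ethyl, methoxy or dimethylamino on the carbonyl carbon would separate these. Compound 1 and compound 2 differ from compound 3 in more than one place, so they do not settle what a plain amino group does here.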